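The compounds below may be only part of what the source reports. "The series", "measured", "known", "first", "only" and "open" are said of these compounds alone.

Working notes on the series. Compound 1 `C=C1CCCC(C)(C)C1(O)CC/C(C)=C/CC[C@]1(C)CC[C@@H]([C@@H](C)C(=O)OC)OO1` sits at the weak end of the three measured compounds: in a functional assay on IGRO cells (Homo sapiens) for cytotoxicity, read by colony formation (on this read-out higher numbers stand for weaker inhibition of growth and lower numbers for stronger inhibition of growth), compound 1 gives 2420 nM, the highest of the three numbers. Compound 3 `C=C1CCCC(C)(C)C1CC[C@]1(C)CC[C@H]([C@@H](C)C(=O)OC)OO1` gives 500 nM in this assay, a gap to compound 1 beyond the scatter, and compound 2 `C=C1CCC[C@H]2[C@](C)(CC[C@]3(C)CC[C@H]([C@@H](C)C(=O)O)OO3)[C@@H](C)CC[C@]12C` gives 120 nM in this assay, the furthest from compound 1 and also beyond the scatter. Going by the values given here, no two of these measured compounds differ in a single place, so no step within the measured set can be isolated.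

Compound 4 `C=C1CCCC(C)(C)C1(O)CC/C(C)=C/CC[C@]1(C)CC[C@H]([C@@H](C)C(=O)OC)OO1` is still to be measured in this assay. It differs from compound 1 as follows: the two compounds have the same atoms and bonds; at least one stereo element is drawn with a configuration in one of them and without one in the other: 1 of 5 stereo elements differ; a stereocentre at a saturated ring carbon is drawn S in compound 1 and R in compound 4. Among the compounds with values here, no measured pair shows the effect of this change on its own, so the direction is open; an inversion at a saturated ring carbon can shift a number either way, but nothing here says it must. The change is expected to amount to a 1.3-fold lower number from compound 1 to compound 4 (0.13 log units; within the scatter), a step that need not exceed the scatter. For compound 4 the estimate in this assay is 1800 nM, with a range from 400 nM to 8000 nM.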

Compound 4, concentration for 50% growth inhibition: > 5000 nM
Compound 4: a limit, no number; the forecaster's own chance of this, stated with the estimate: 5%; at least 2.7-fold (0.44 log units) between middle value and limit.
By their numbers in this assay, from the lowest: compound 2; then compound 3; then compound 1. At a limit, above all of these: compound 4.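

Compound 4 gives > 5000 nM in this assay, which is a limit of the assay and not a number. Inversion at this saturated ring carbon, S to R with atoms and bonds unchanged, gives an at least 2.0-fold higher number from compound 1 to compound 4 (0.31 log units; beyond the scatter): this is the first step in the series confined to one place, and it shows that the configuration at this stereocentre counts on this read-out, with the S form the stronger of the pair. One caveat applies to this comparison: the fact that one of compounds 1 and 4 is drawn with a defined configuration and the other without, at the place where they differ

From the compounds shown here alone, the full size of the step stays open because only a limit is available: the limit of > 5000 nM in this assay, at which 1 of the 4 values shown sits. Whether the same inversion acts in the same direction with an amide in place of the methyl ester also stays open.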